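The compounds below may be only part of what the source reports. "The series", "measured", "known", "first", "only" and "open" are said of these compounds alone.

Compound 1 `COc1cc2c(Oc3ccc(NC(=O)c4cc(-c5ccccc5C)ccn4)cc3F)ccnc2cc1OCCCN1CCN(C)CC1` and compound 2 `COc1cc2c(Oc3ccc(NC(=O)c4cc(-c5ccccc5F)ccn4)cc3F)ccnc2cc1OCCCN1CCN(C)CC1` share one core and differ in a single place: fluoro in place of methyl on an aromatic carbon. In a functional assay on MKN-45 cells (Homo sapiens) for cytotoxicity, read by MTT assay, with a stated time of 72 h (on this read-out higher numbers stand for weaker inhibition and lower numbers for stronger inhibition), compound 1 gives 240 nM, and compound 2 gives 150 nM, so that the change made a 1.6-fold lower number from compound 1 to compound 2 (0.20 log units; within the scatter).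

Compound 3 `COc1cc2c(Oc3ccc(NC(=O)c4nccc(-c5ccc(C)cc5)n4)cc3F)ccnc2cc1OCCCN1CCN(C)CC1` is built on a second core; how that core differs from the core of compound 1 is not broken down here. In this assay compound 3 gives 340 nM, a higher number than compound 2 shows, while compound 3 and compound 1 lie within the scatter of each other.

Compound 4 `COc1cc2c(Oc3ccc(NC(=O)c4nccc(-c5ccc(F)cc5)n4)cc3F)ccnc2cc1OCCCN1CCN(C)CC1` has not yet been measured. It differs from compound 3 by fluoro in place of methyl on an aromatic carbon. Among the compounds with values here, this is the same kind of change as the one from compound 1 to compound 2, but not the same: in the pair on the first core the fluoro stands ortho to a large group, whereas on the second core it stands para to a large group.

Since the change from compound 1 to compound 2 gave a 1.6-fold lower number from compound 1 to compound 2 (0.20 log units; within the scatter), a step of similar modest size is expected here, and so the estimated step is a 1.4-fold lower number from compound 3 to compound 4 (0.15 log units; within the scatter). This rests only on one measured pair, on a different core and at a different place, so the expectation is held loosely. Compound 4 is therefore estimated at 240 nM, with a likely range from 110 nM to 520 nM.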

Compound 4, half-maximal inhibitory concentration: 90 nM
Estimate against measurement, compound 4: 2.7-fold (0.43 log units) above; measured number outside the range, below it.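

In this assay, putting fluoro in place of methyl, the change from 4-methylphenyl to 4-fluorophenyl, gave a 3.8-fold lower number from compound 3 to compound 4 (0.58 log units; beyond the scatter) on the core of compound 3, so on this core the step stands clear of the usual variation between repeats. Set beside the step on the core of compound 1, the two point the same way and their sizes cannot be told apart: the same change on two cores in this assay, a 1.6-fold lower number (0.20 log units; within the scatter) from compound 1 to compound 2 and a 3.8-fold lower number (0.58 log units; beyond the scatter) from compound 3 to compound 4, 2.4-fold (0.37 log units) apart, within the scatter of two such steps. Within the data shown here, the change therefore goes with a lower number on both cores, although only the step on the core of compound 3 is beyond the scatter, and the two pairs do not show that the core alters the size of the step, nor can they separate any influence of the core from that of the different place of the fluoro.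

Among these compounds, with only two pairs in hand, it remains open whether the same direction would hold for a chloro, methoxy or nitrile group at these places, or for an amine or a carboxylic acid there. As far as these compounds go, it is equally open whether fluoro in place of methyl would give a lower number on further cores, or in any read-out other than this assay.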